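From 3,4-Difluorophenyl to 3-Chlorophenyl on the Shared Core

The source may hold more compounds than are shown below. What is called first, only, known or untested is meant among the compounds shown, and "the series" means these compounds.

Measured compounds:
compound 1 `Cc1nn(C)c(Oc2cccc(F)c2)c1/C=N\CCCCCCOc1cc2oc(=O)cc(C)c2cc1Cl` — 23600 nM
compound 2 `Cc1nn(C)c(Oc2ccc(F)cc2F)c1/C=N\CCCCCCOc1cc2oc(=O)cc(C)c2cc1Cl` — > 25000 nM
compound 3 `Cc1nn(C)c(Oc2ccc(F)c(F)c2)c1/C=N\CCCCCCOc1cc2oc(=O)cc(C)c2cc1Cl` — > 25000 nM

Three compounds share one core and differ only in the fluorinated phenyl ring on the oxygen. In a functional assay on SMMC-7721 cells (Homo sapiens) for antiproliferative activity, read by MTT assay, with a stated time of 72 h (on this read-out lower numbers stand for stronger inhibition and higher numbers for weaker inhibition), compound 1 gives 23600 nM. Compound 2 returns only a limit of this assay, > 25000 nM, not a number. Compound 3 likewise returns only a limit, > 25000 nM. So compound 3 stands with compound 2 at the weak end of what this assay can report (the limit of > 25000 nM in this assay, at which 2 of the 3 values shown sit), while compound 1 is the one compound with a readable number.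

Compound 4 `Cc1nn(C)c(Oc2cccc(Cl)c2)c1/C=N\CCCCCCOc1cc2oc(=O)cc(C)c2cc1Cl` is not yet measured. It differs from compound 3 in one place: 3-chlorophenyl in place of 3,4-difluorophenyl on an oxygen on an aromatic ring. The nearest measured steps are an at least 1.0-fold higher number from compound 1 to compound 3 (0.02 log units; that floor lies within the scatter) and a step that the two limits leave unreadable from compound 2 to compound 3; neither shows a change that rises clearly out of the scatter, and the second cannot be read at all. Nothing measured therefore points to a strong shift in this assay in either direction.

Compound 4 is accordingly expected near 22000 nM, in a range from 8000 nM to 60000 nM. That estimate implies a step of an at least 1.1-fold lower number from compound 3 to compound 4 (0.05 log units; that floor lies within the scatter), and it is expected to stay within the scatter, with a fair chance that compound 4 also reports only a limit.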

Compound 4, half-maximal inhibitory concentration: 5260 nM
Compound 4: the middle estimate sits 4.2-fold (0.62 log units) above what was measured; measured number below the stated range.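

In this assay, for the compounds shown here, this position on the oxygen proves able to move the result: no step among the fluorinated rings could be read as rising out of the scatter, whereas 3-chlorophenyl brings an at least 4.7-fold lower number from compound 3 to compound 4 (0.67 log units; beyond the scatter) and an at least 4.7-fold lower number from compound 2 to compound 4 (0.67 log units; beyond the scatter). The plainest comparison is a 4.5-fold lower number from compound 1 to compound 4 (0.65 log units; beyond the scatter), where chloro replaces fluoro on an aromatic carbon and nothing else changes. Compound 2 and compound 3 each report only a limit, so the true size of the first two steps stays open: the limit of > 25000 nM in this assay, at which 2 of the 4 values shown sit.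

Still unsettled is whether this gain is particular to chloro or would persist with bromo or trifluoromethyl in its place. The compounds shown also cannot tell how an amine or a carboxylic acid on this ring would fare.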